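Acetyl in place of methyl on the ring nitrogen: compound 4

A few compounds are considered here, and "the series" means these few. Any claim that something is new, unique, unknown or untested is made for them only; others in the source may bear on it.

Measured so far in a functional assay on the whole organism (plasma, strain albino) for inhibition, with Rattus norvegicus as the target, with stated times of 1 h and 4 h, at a dose of 25 mg/kg by the oral route; on this read-out higher numbers stand for a stronger effect at the one dose given and lower numbers for a weaker effect:
Compound 1 `COc1ccc(C2CC(c3ccc(NC(=O)c4cc(Cl)ccc4OC)cc3)=NN2C)cc1` gives 69.6%.
Compound 2 `COc1ccc(Cl)cc1C(=O)Nc1ccc(C2=NN(C)C(c3ccccc3[N+](=O)[O-])C2)cc1` gives 83.8%.
Compound 3 `COc1ccc(Cl)cc1C(=O)Nc1ccc(C2=NN(C)C(c3ccc([N+](=O)[O-])cc3)C2)cc1` gives 71.4%.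

Compound 2 stands highest of the three numbers. The step of a number 12.4 percentage points lower from compound 2 to compound 3 (beyond the scatter) and the step of a number 14.2 percentage points higher from compound 1 to compound 2 (beyond the scatter) both lie beyond the scatter, while the step of a number 1.8 percentage points higher from compound 1 to compound 3 (within the scatter) stays within it.

Compound 4 `COc1ccc(Cl)cc1C(=O)Nc1ccc(C2=NN(C(C)=O)C(c3ccccc3[N+](=O)[O-])C2)cc1` keeps everything of compound 2 except one change: acetyl in place of methyl on an amine nitrogen in a ring. Within the data shown here, none of the measured steps touches this amine nitrogen in a ring; all three vary the group on the saturated ring carbon or its substituent. Among the measured compounds shown here, they therefore give no direct guide to the size or direction of a change in this assay here, and the only anchor is the value of compound 2. For the measured compounds named here, the acetyl brings one hydrogen-bond acceptor where the methyl had none, but no measured pair shows what that does. The step of a number 7.8 percentage points lower from compound 2 to compound 4 (within the scatter) is expected to be small, with wide uncertainty. Compound 4 is estimated at 76%, expected to fall between 56% and 90%.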

Compound 4, a percentage reported as inhibition, in the whole organism at one dose (the size of the read-out at that dose, not a potency): 77.2%
The estimate for compound 4 lay 1.2 percentage points below the measured number; measured number inside the range.
By their numbers in this assay, from the lowest: compounds 1, 3, 4 and 2 (each within the scatter of the next, the first and the last beyond it).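

In this assay, among these compounds, the first change at the amine nitrogen in a ring, acetyl in place of methyl, gives a number 6.6 percentage points lower from compound 2 to compound 4 (within the scatter), so compound 2 and compound 4 cannot be told apart on this read-out. The position therefore takes acetyl, with 3 heavy atoms and 1 hydrogen-bond acceptor, in place of methyl without a step beyond the scatter, at least when the saturated ring carbon bears the 2-nitrophenyl group. No measured data bear on why this step has the size it has.

This single pair leaves open whether the same exchange behaves alike with the 4-methoxyphenyl group of compound 1 or the 4-nitrophenyl group of compound 3. It also leaves open how a longer acyl chain such as butyryl, a benzoyl group or a plain hydrogen would fare on this nitrogen.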